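Adding Fluorine to the Methylphenyl Amide of Compound 2

This account rests on a few compounds, and the source may have more. Where it says the series, first, only, none or still open, it means among the compounds named here.

Measured compounds:
compound 1 `O=C(Nc1cccc(-c2oc3cc(-c4ccc(F)cc4)ccc3c(=O)c2O)c1)c1ccccc1F`: 10800 nM
compound 2 `Cc1ccc(C(=O)Nc2cccc(-c3oc4cc(-c5ccc(F)cc5)ccc4c(=O)c3O)c2)cc1`: 7110 nM
compound 3 `Cc1ccccc1C(=O)Nc1cccc(-c2oc3cc(-c4ccc(F)cc4)ccc3c(=O)c2O)c1`: 9900 nM

In a functional assay on HCC1937 cells (Homo sapiens) for antiproliferative activity, read by CCK-8 assay, with a stated time of 72 h (a higher number here means a weaker inhibitor, a lower number a stronger inhibitor), compound 2 gives the lowest of the three numbers, but its steps to the others, a 1.5-fold lower number from compound 1 to compound 2 (0.18 log units; within the scatter) and a 1.4-fold higher number from compound 2 to compound 3 (0.14 log units; within the scatter), lie within the scatter, so no order among them can be claimed. Compound 4 `Cc1cc(C(=O)Nc2cccc(-c3oc4cc(-c5ccc(F)cc5)ccc4c(=O)c3O)c2)ccc1F` differs from compound 2 by 4-fluoro-3-methylphenyl in place of 4-methylphenyl on a carbonyl carbon. For the measured compounds named here, the steps that bear on this change are the earlier swaps on the same carbonyl carbon, a 1.5-fold lower number from compound 1 to compound 2 (0.18 log units; within the scatter) and a 1.4-fold higher number from compound 2 to compound 3 (0.14 log units; within the scatter), together with a 1.1-fold lower number from compound 1 to compound 3 (0.04 log units; within the scatter); none moved beyond the scatter. A fluorine entering beside the retained methyl is therefore expected to leave the number roughly where compound 2 stands. Compound 4 is estimated at 7500 nM, between 4000 nM and 14000 nM, which means an expected 1.1-fold higher number from compound 2 to compound 4 (0.02 log units; within the scatter).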

Compound 4, half-maximal inhibitory concentration: 5420 nM
Compound 4: middle estimate off by 1.4-fold (0.14 log units), on the high side; the range from low to high includes it.
By their numbers in this assay, from the lowest: compounds 4, 2, 3 and 1 (each within the scatter of the next).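

With 4-fluoro-3-methylphenyl in place of 4-methylphenyl on the carbonyl carbon, a ring carrying both a fluoro and a methyl group stays within the scatter of compound 2 (a 1.3-fold lower number from compound 2 to compound 4 (0.12 log units; within the scatter)). The same holds against the 2-methylphenyl amide (a 1.8-fold lower number from compound 3 to compound 4 (0.26 log units; within the scatter)) and the 2-fluorophenyl amide (a 2.0-fold lower number from compound 1 to compound 4 (0.30 log units; within the scatter)), so this position still separates none of the four compounds. Nothing available explains these small steps.

As far as these compounds go, it remains open whether an amine or a carboxylic acid on this ring, or a longer chain in its place, would move the number beyond the scatter.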